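The source may hold more compounds than are shown below. What is called first, only, known or untested is meant among the compounds shown, and "the series" means these compounds.

For the measured compounds named here, in a functional assay on NCI-H460 cells (Homo sapiens) for inhibition, read by sulforhodamine B assay, with a stated time of 48 h (a lower number here means a stronger inhibitor of growth, a higher number a weaker inhibitor of growth), compound 1 `O=C(Cc1csc2nc(-c3ccc(Br)cc3)cn12)N/N=C/c1ccccc1` gives 52500 nM and compound 2 `O=C(Cc1csc2nc(-c3ccc(Br)cc3)cn12)N/N=C/c1ccccc1O` gives 15800 nM as the lower of the two numbers so far, which makes compound 2 the stronger inhibitor of growth of this pair. Compound 3 `O=C(Cc1csc2nc(-c3ccc(Br)cc3)cn12)N/N=C/c1ccc(O)cc1` has the same atoms as compound 2 joined differently, with 4-hydroxyphenyl in place of 2-hydroxyphenyl on a carbon with a double bond to nitrogen. Going by the values given here, only one measured step bears on this change. That step is a 3.3-fold lower number from compound 1 to compound 2 (0.52 log units; beyond the scatter) when hydroxy replaces hydrogen on an aromatic carbon, and it is modest though beyond the scatter. Among the compounds with values here, compound 3 also carries a hydroxy group, but no measured pair shows what changing 2-hydroxyphenyl to 4-hydroxyphenyl does, so the data give no firm direction. No step beyond the scatter is therefore expected in this assay and the uncertainty stays wide, reaching up towards the number for compound 1. The expected step is a 1.1-fold higher number from compound 2 to compound 3 (0.06 log units; within the scatter) as a best guess. Compound 3 is expected to give an estimated 18000 nM (expected range 6000 nM to 54000 nM).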

Compound 3, concentration for 50% growth inhibition: 57500 nM
Compound 3: middle estimate off by 3.2-fold (0.50 log units), on the low side; measured number above the stated range.
By their numbers in this assay, from the lowest: compound 2; then compounds 1 and 3 (each within the scatter of the next).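

In this assay, the effect of the hydroxy group depends on where it stands on the phenyl ring: exchanging 2-hydroxyphenyl for 4-hydroxyphenyl on the carbon with a double bond to nitrogen gives a 3.6-fold higher number from compound 2 to compound 3 (0.56 log units; beyond the scatter). Hydroxy in place of hydrogen on an aromatic carbon, this time as the 4-hydroxyphenyl group, gives only a 1.1-fold higher number from compound 1 to compound 3 (0.04 log units; within the scatter), so the gain seen with compound 2 does not come from carrying a hydroxy group as such, and among these three compounds only the 2-hydroxyphenyl group goes with a lower number beyond the scatter. Nothing available explains why the two arrangements of the same atoms differ in this way.

It remains open whether the hydroxy group itself is what matters in compound 2, since the compounds shown do not tell what a methoxy group or an amine in place of that hydroxy would give. They also leave open whether a second hydroxy group on the same ring, or a chlorine in place of the bromine on the shared core, would move the number further.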